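This account rests on a few compounds, and the source may have more. Where it says the series, first, only, none or still open, it means among the compounds named here.

Compound 1, `CCCCCCCCCCCCCCc1ccccc1C(SCCC(=O)O)SCCC(=O)O`, is the longest-chained member of the set; in an assay on membranes from lung (Cavia porcellus) for binding affinity to cysteinyl leukotriene receptor (Homo sapiens) (on this read-out higher numbers stand for weaker inhibition and lower numbers for stronger inhibition), compound 1 gives 1250 nM. Compound 2, `CCCCCCCCCCc1ccccc1C(SCCC(=O)O)SCCC(=O)O`, carries the same two acid-bearing thioether arms on the same core but a shorter chain, and in this assay compound 2 gives 1180 nM. Compound 2 and compound 1 therefore sit within the scatter of each other, and the third value in the set is not a number at all. Compound 3, `CCCCc1ccccc1C(SCCC(=O)O)SCCC(=O)O`, reaches only (the limit of > 20000 nM in this assay, at which 1 of the 3 values shown sits); in this assay compound 3 is reported as > 20000 nM, a limit of the assay rather than a number.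

The steps from these three are of two kinds. Removing four chain carbons far out along the chain gave a 1.1-fold lower number from compound 1 to compound 2 (0.03 log units; within the scatter). Cutting the chain back close to the aromatic carbon gave an at least 16-fold higher number from compound 1 to compound 3 (1.20 log units; beyond the scatter) and an at least 16-fold higher number from compound 2 to compound 3 (1.22 log units; beyond the scatter), both large.

Compound 4, `C#CCCCCCCCCCCc1ccccc1C(SCCC(=O)O)SCCC(=O)O`, differs from compound 2 by ethynyl in place of hydrogen on a saturated chain carbon, ten or more bonds along the chain from an aromatic carbon. The step from compound 1 to compound 2, at the same far-out place, is the one that bears on it, and it was within the scatter. The two large steps concern the chain near the aromatic carbon, not its far end. No change beyond the scatter is therefore expected in this assay for compound 4, which is estimated at 1100 nM, between 500 nM and 2500 nM; this estimate means a step of a 1.1-fold lower number from compound 2 to compound 4 (0.03 log units; within the scatter).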

Compound 4, inhibition constant: 141 nM
For compound 4 the middle estimate is 7.8-fold (0.89 log units) above the measured one, and the stated range ends above it.
By their numbers in this assay, from the lowest: compound 4; then compounds 2 and 1 (each within the scatter of the next). At a limit, above all of these: compound 3.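

Far out along the chain, the earlier compounds had shown no change beyond the scatter, yet in this assay ethynyl in place of hydrogen on a saturated chain carbon, ten or more bonds along the chain from an aromatic carbon, gives an 8.4-fold lower number from compound 2 to compound 4 (0.92 log units; beyond the scatter), and ethynyl in place of butyl gives an 8.9-fold lower number from compound 1 to compound 4 (0.95 log units; beyond the scatter). The far end of the chain is therefore not indifferent in this series: what stands there can move the number beyond the scatter, even though the shortening from compound 1 to compound 2 did not. Compound 3 stands at a limit and not at a number, so the step of an at least 140-fold lower number from compound 3 to compound 4 (2.15 log units; beyond the scatter) is only a bound: the limit of > 20000 nM in this assay, at which 1 of the 4 values shown sits.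

A dodecyl chain at this place would separate the effect of the triple bond from that of the chain length, and the compounds shown do not settle that question. From the compounds shown here alone, how a nitrile or a hydroxyl at the same far-out carbon would read in this assay also remains open.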